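The source may report more compounds than this note shows. Statements on the series, on what has been measured and on what is new or still open speak of the compounds shown alone.

Measured compounds:
- compound 1 `CCNC(=O)c1noc(-c2cc(C(C)C)c(O)cc2O)c1-c1cc(CNC(C)C)no1`: in a functional assay on A2780 cells (Homo sapiens) for inhibition (on this read-out higher numbers stand for weaker inhibition and lower numbers for stronger inhibition), compound 1 gives 38 nM
- compound 2 `CCNC(=O)c1noc(-c2cc(C(C)C)c(O)cc2O)c1-c1cc(CNC(=O)CC)no1`: in this assay compound 2 gives "not determined" (no result reported)
- compound 3 `CCNC(=O)c1noc(-c2cc(C(C)C)c(O)cc2O)c1-c1cc(CNCCO)no1`: in this assay compound 3 gives "not determined" (no result reported)

Compound 3 therefore stands without a number in this assay; it shares this position with compound 2, which also has no result. Of the three measured compounds, only compound 1 carries a value, and it is the sole anchor for what follows.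

Compound 4 `CCNC(=O)c1noc(-c2cc(C(C)C)c(O)cc2O)c1-c1cc(C(N)=O)no1` is the next step from compound 3. The change is carbamoyl in place of ((2-hydroxyethyl)amino)methyl on an aromatic carbon. In other words, the group on the five-membered aromatic ring is replaced, while the shared core stays unchanged. With no number for compound 3, the size and direction of this step in this assay cannot be checked against a measured pair.

Judged against compound 1 as the only measured point, compound 4 is expected to remain an inhibitor in this assay, with an estimated value of 120 nM, in a range from 25 nM to 600 nM.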

Compound 4, half-maximal inhibitory concentration: 15 nM
Compound 4: middle estimate off by 8.0-fold (0.90 log units), on the high side; measured number outside the range, below it.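

In this assay there is a 2.5-fold lower number from compound 1 to compound 4 (0.40 log units; beyond the scatter), so at this place on the five-membered ring the (isopropylamino)methyl group can give way to the smaller carbamoyl group without loss of inhibition, and the number even improves beyond the scatter. An amine in this side group is therefore not required for a low number on the shared core. Compound 2 and compound 3 have no number, so the steps involving them cannot be read, and no measurement shown here explains the lower number of compound 4.

The compounds shown leave open how a carboxylic acid or a nitrile at this place would compare with carbamoyl. They also leave open whether a methyl group on the carbamoyl nitrogen would keep the low number.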